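The compounds below may be only part of what the source reports. "The series", "measured", "known", "first", "only" and "open" are said of these compounds alone.

Measured in a functional assay on HeLa cells (Homo sapiens) for inhibition, read by CCK-8 assay, with a stated time of 48 h; a lower number here means a stronger inhibitor, a higher number a weaker inhibitor:
- compound 1 `COc1cc(-c2ccnc3cc(-c4cn(CO)c5ccccc45)nn23)cc(OC)c1OC`: 103 nM
- compound 2 `COc1cc(-c2ccnc3cc(-c4ccc(C)cc4)nn23)cc(OC)c1OC`: 21 nM
- compound 3 `COc1cc(-c2ccnc3cc(-c4ccc(C(F)(F)F)cc4)nn23)cc(OC)c1OC`: 1840 nM

Compound 2 has the lowest number of the three, making it the strongest inhibitor measured so far. Compound 4 `COc1cc(-c2ccnc3cc(-c4ccc(N(C)C)cc4)nn23)cc(OC)c1OC` keeps the rest of compound 2 but carries dimethylamino in place of methyl on an aromatic carbon. For the measured compounds named here, only one measured step changes this same group, trifluoromethyl in place of methyl, and it was large: an 88-fold higher number from compound 2 to compound 3 (1.94 log units; beyond the scatter). That single step shows the group can matter, but it cannot fix the outcome for a different group. A moderate weakening is therefore expected, with the estimated step being a 2.4-fold higher number from compound 2 to compound 4 (0.38 log units; beyond the scatter). For compound 4 the estimate is 50 nM, with an expected range of 10 nM to 300 nM.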

Compound 4, half-maximal inhibitory concentration: 378 nM
For compound 4 the middle estimate is 7.6-fold (0.88 log units) below the measured one; the whole stated range lies below it.
By their numbers in this assay, from the lowest: compound 2; then compound 1; then compound 4; then compound 3.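

In this assay, dimethylamino is a second replacement for methyl on this ring that gives a large rise, an 18-fold higher number from compound 2 to compound 4 (1.26 log units; beyond the scatter), so compound 2 stays ahead of both replacements measured at this position. The two replacements also differ from each other, with a 4.9-fold lower number from compound 3 to compound 4 (0.69 log units; beyond the scatter), so the outcome depends on which group enters rather than on the loss of methyl alone. Nothing measured here explains these differences.

Still open, from the compounds shown here alone, is whether ethyl, chlorine or a primary amine at this position would match compound 2 or fall closer to compound 4.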